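Aryl swap on the shared core: compound 2 to compound 4

The compounds below may be only part of what the source reports. "The series", "measured", "known", "first", "only" and "open" are said of these compounds alone.

Compound 2 `CN(C)CCn1c(=O)c(=Cc2ccc(F)cc2F)s/c1=C1\C(=O)Nc2cc(F)ccc21` stands second highest of the three numbers in a functional assay on MDA-MB-231 cells (Homo sapiens) for inhibition, read by MTT assay, with a stated time of 72 h (on this read-out higher numbers stand for weaker inhibition and lower numbers for stronger inhibition), with 8440 nM; compound 1 `CN(C)CCn1c(=O)c(=Cc2ccc(F)c(F)c2)s/c1=C1\C(=O)Nc2cc(F)ccc21` gives 25000 nM, while compound 3 `CCN(CC)CCCn1c(=O)c(=Cc2ccc(O)cc2)s/c1=C1\C(=O)Nc2ccc(C)cc21` gives 1810 nM. Compound 3 differs from compound 2 in several places at once. Compound 4 `COc1ccc(C=c2s/c(=C3\C(=O)Nc4cc(F)ccc43)n(CCN(C)C)c2=O)cc1` is not yet measured; the change is 4-methoxyphenyl in place of 2,4-difluorophenyl on a double-bonded chain carbon bound to an aromatic carbon. Among the compounds with values here, the only measured step at this place is a 3.0-fold lower number from compound 1 to compound 2 (0.47 log units; beyond the scatter), a shift between two fluorinated rings. Within the data shown here, no step to a ring carrying a methoxy group has been measured; compound 3 carries a hydroxy ring but also other changes, so its value is only a loose pointer. A step of similar modest size is therefore expected, leaning lower. Compound 4 is estimated at 6000 nM (range 2000 nM to 20000 nM), an expected step of a 1.4-fold lower number from compound 2 to compound 4 (0.15 log units; within the scatter).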

Compound 4, half-maximal inhibitory concentration: 2090 nM
Beside the measured number, compound 4's estimate is 2.9-fold (0.46 log units) above it; the range from low to high includes it.
By their numbers in this assay, from the lowest: compounds 3 and 4 (each within the scatter of the next); then compound 2; then compound 1.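

In this assay the place on a double-bonded chain carbon bound to an aromatic carbon accepts a ring without fluorine, with 4-methoxyphenyl giving a 4.0-fold lower number from compound 2 to compound 4 (0.61 log units; beyond the scatter) and a 12-fold lower number from compound 1 to compound 4 (1.08 log units; beyond the scatter) on the shared core. The span at this place is thus wider than a 3.0-fold lower number from compound 1 to compound 2 (0.47 log units; beyond the scatter) seen between the two fluorinated rings, and the three rings fall in the order 3,4-difluorophenyl, 2,4-difluorophenyl, 4-methoxyphenyl. No available evidence bears on this result.

As far as these compounds go, whether the gain follows from losing fluorine or from gaining methoxy stays open. An unsubstituted phenyl ring, or a phenyl ring carrying an amine or a carboxylic acid, would help to separate the two.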